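Cyclopropyl for bromo on the shared core: expected binding

The source may report more compounds than this note shows. Statements on the series, on what has been measured and on what is new or still open speak of the compounds shown alone.

Measured compounds:
compound 1, `OC(Cc1ccccc1)c1cc(Br)cc2[nH]ncc12`: 2200 nM
compound 2, `C#Cc1cc(C(O)Cc2ccccc2)c2cn[nH]c2c1`: 94000 nM

Working notes. Both compounds were tested in an assay for binding affinity to Indoleamine 2,3-dioxygenase 1 variant C129Y (Homo sapiens), read by spectrophotometry, with a stated time of 30 min; on this read-out higher numbers stand for weaker binding and lower numbers for tighter binding. For the measured compounds named here, compound 1 gives the lower of the two numbers, and the only neighbouring measurement is compound 2, reached by putting ethynyl in place of bromo on an aromatic carbon; that step gives a 43-fold higher number from compound 1 to compound 2 (1.63 log units; beyond the scatter).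

The new compound is compound 3, `OC(Cc1ccccc1)c1cc(C2CC2)cc2[nH]ncc12`. It differs from compound 1 by cyclopropyl in place of bromo on an aromatic carbon.

Going by the values given here, the one step that bears on it is the bromo-to-ethynyl exchange at the same aromatic carbon, which weakened binding far beyond the scatter. Cyclopropyl is, like ethynyl, a carbon group entering where bromo leaves, but it is not ethynyl, and no other carbon group has been measured at this position. The expectation is therefore a step in the same direction as from compound 1 to compound 2, but smaller: for compound 3 the expected change is a 4.5-fold higher number from compound 1 to compound 3 (0.66 log units; beyond the scatter). Compound 3 is estimated at 10000 nM, with a range from 2500 nM to 60000 nM.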

Compound 3, dissociation constant: 28000 nM
Compound 3: the middle estimate sits 2.8-fold (0.45 log units) below what was measured; the measured number falls inside the stated range.
By their numbers in this assay, from the lowest: compound 1; then compound 3; then compound 2.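

In this assay a second carbon group at this aromatic carbon also costs binding relative to bromo, with a 13-fold higher number from compound 1 to compound 3 (1.10 log units; beyond the scatter), so the loss seen on leaving bromo is no longer tied to ethynyl alone. The two carbon groups are not interchangeable, however: a 3.4-fold lower number from compound 2 to compound 3 (0.53 log units; beyond the scatter), which shows that the identity of the entering group still matters at this position, even though neither group recovers the binding of compound 1. Among the three groups shown, bromo therefore gives the tightest binding and ethynyl the weakest, but nothing at hand explains this order.

The compounds shown leave open whether the advantage belongs to bromo specifically or extends to other halogens such as chloro or iodo, and whether methyl or an amine at the same carbon would sit closer to compound 1 than to compound 3. They also leave open whether this order of bromo, cyclopropyl and ethynyl would hold if the group of 9 heavy atoms on the shared core were changed.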